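The compounds below may be only part of what the source reports. "The series", "measured", "known", "first", "only" and "open" are said of these compounds alone.

Measured so far:
compound 1 `COc1cc(-c2cc(/C=C/C(=O)c3ccc(N)cc3)[nH]n2)cc(OC)c1OC` — 8320 nM
compound 2 `COc1cc(-c2cc(/C=C/C(=O)c3ccc(Cl)c(Cl)c3)[nH]n2)cc(OC)c1OC` — 18800 nM
compound 3 `COc1ccc(C(=O)/C=C/c2cc(-c3cc(OC)c(OC)c(OC)c3)n[nH]2)cc1OC` — 7820 nM

In a functional assay on SK-OV-3 cells (Homo sapiens) for inhibition, read by sulforhodamine B assay, with a stated time of 48 h (on this read-out higher numbers stand for weaker inhibition of growth and lower numbers for stronger inhibition of growth), compound 1 sits close to compound 3, the two being within the scatter of each other (a 1.1-fold lower number from compound 1 to compound 3 (0.03 log units; within the scatter)), while compound 2 gives a higher number (a 2.3-fold higher number from compound 1 to compound 2 (0.35 log units; beyond the scatter)). Compound 4 `COc1ccc(C(=O)/C=C/c2cc(-c3cc(OC)c(OC)c(OC)c3)n[nH]2)cc1` is compound 1 with one change: methoxy in place of amino on an aromatic carbon. Among the measured compounds shown here, the step bearing most directly on this is the one from compound 1 to compound 3, where a methoxy-bearing aryl replaced the 4-aminophenyl without a shift beyond the scatter; the step from compound 2 to compound 3 (a 2.4-fold lower number from compound 2 to compound 3 (0.38 log units; beyond the scatter)) shows methoxy-bearing aryl on the low side of dichloro. A step of no more than the scatter is therefore expected, in either direction. Compound 4 is estimated at 9000 nM (range 4000 nM to 20000 nM), an expected step of a 1.1-fold higher number from compound 1 to compound 4 (0.03 log units; within the scatter).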

Compound 4, concentration for total growth inhibition: 20500 nM
Compound 4: the middle estimate sits 2.3-fold (0.36 log units) below what was measured; the measured number lies above the stated range.
By their numbers in this assay, from the lowest: compounds 3 and 1 (each within the scatter of the next); then compounds 2 and 4 (each within the scatter of the next).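

In this assay, this position on the aryl carbonyl substituent proves responsive to a change of one group: methoxy in place of amino is not neutral here (a 2.5-fold higher number from compound 1 to compound 4 (0.39 log units; beyond the scatter)), and the 4-methoxyphenyl of compound 4 does not match the 3,4-dimethoxyphenyl of compound 3, since hydrogen in place of the other methoxy also moves the number (a 2.6-fold higher number from compound 3 to compound 4 (0.42 log units; beyond the scatter)). The 4-methoxyphenyl ends level with the 3,4-dichlorophenyl (a 1.1-fold higher number from compound 2 to compound 4 (0.04 log units; within the scatter)). Nothing at hand accounts for these steps. From the compounds shown here alone, whether a hydroxy or dimethylamino group on this aromatic carbon would stay with compound 1 or with compound 4 remains open.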